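A few compounds are considered here, and "the series" means these few. Any claim that something is new, unique, unknown or untested is made for them only; others in the source may bear on it.

Compound 1, with structure `COc1ccc(N)c(C(O)CCNC(=N)c2ccccc2)c1`, gives 95.9% in an assay for inhibition of Nitric oxide synthase, inducible (Homo sapiens), with a stated time of 30 min, tested at 1 mM; on this read-out lower numbers stand for less inhibition and higher numbers for more inhibition at the one concentration tested (going by the name of the read-out). Compound 2, with structure `COc1ccc(N)c(C(O)CCNC(=N)c2ccc(Cl)cc2)c1`, gives 81% in this assay. Among the measured compounds shown here, the one change between them is chloro in place of hydrogen on an aromatic carbon, and it made a step of a number 14.9 percentage points lower from compound 1 to compound 2 (beyond the scatter).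

Compound 3, with structure `COc1ccc(N)c(C(=O)CCNC(=N)c2ccccc2)c1`, gives 94.7% in this assay; its value and that of compound 1 lie within the scatter of each other. The difference between the two cores of compound 1 and compound 3 is not broken down here.

Compound 4, with structure `COc1ccc(N)c(C(=O)CCNC(=N)c2ccc(Cl)cc2)c1`, has not yet been measured. It differs from compound 3 by chloro in place of hydrogen on an aromatic carbon, the same change as from compound 1 to compound 2, at the same place. Because compound 3 gives 94.7% close to compound 1, the step from compound 3 to compound 4 is expected to be about a number 13.7 percentage points lower from compound 3 to compound 4 (beyond the scatter). Compound 4 is therefore estimated at 81%, between 68% and 92%.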

Compound 4, a percentage reported as inhibition, at one concentration (the size of the read-out at that concentration, not a potency): 75.1%
The estimate for compound 4 lay 5.9 percentage points above the measured number; low and high end bracket the measured number.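

In this assay, chloro in place of hydrogen on an aromatic carbon lowers the number on the core of compound 3 as well, giving a number 19.6 percentage points lower from compound 3 to compound 4 (beyond the scatter). Set beside the earlier case, the change carries from one core to the other with a step of similar size: the same change on two cores in this assay, a number 14.9 percentage points lower (beyond the scatter) from compound 1 to compound 2 and a number 19.6 percentage points lower (beyond the scatter) from compound 3 to compound 4, 4.7 percentage points apart, within the scatter of two such steps. Among the compounds shown here, this rests on only two pairs of compounds, so it shows the carry-over of phenyl to 4-chlorophenyl on these two cores alone and does not show why the number falls or whether the step would hold on any other core.

The compounds shown leave open what a fluoro or trifluoromethyl group would do in place of the chloro. They also leave open whether the step would stay similar with a longer chain.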